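The source may report more compounds than this note shows. Statements on the series, on what has been measured and on what is new or still open speak of the compounds shown alone.

Among the compounds with values here, in an assay on isolated protein for inhibition of tyrosine-protein kinase receptor UFO (Homo sapiens), read by FRET and Z'-LYTE, with a stated time of 1.5 h (on this read-out higher numbers stand for weaker inhibition and lower numbers for stronger inhibition), compound 2 `Cc1c(C(=O)Nc2ccc(Oc3ncnc4[nH]cc(-c5ccccc5)c34)c(F)c2)c(=O)c2cc(Br)ccc2n1C` gives 3120 nM, the only number so far in this assay. Compound 1 `Cc1c(C(=O)Nc2ccc(Oc3ncnc4[nH]cc(-c5ccccc5)c34)c(F)c2)c(=O)c2cc(F)ccc2n1C` sits at the limit > 10000 nM in this assay. Within the data shown here, the only measured step, an at least 3.2-fold lower number from compound 1 to compound 2 (0.50 log units; beyond the scatter), is bounded for compound 1 by the limit of > 10000 nM in this assay, at which 1 of the 2 values shown sits. Compound 3 `Cc1c(C(=O)Nc2ccc(Oc3ncnc4[nH]cc(-c5ccccc5)c34)c(F)c2)c(=O)c2cc(C(F)(F)F)ccc2n1C` differs from compound 2 by trifluoromethyl in place of bromo on an aromatic carbon. Among the measured compounds shown here, no measured step covers this exchange, and the one known step gives no direction for it. The expected step is a 1.0-fold lower number from compound 2 to compound 3 (0.02 log units; within the scatter), within the scatter. The estimate for compound 3 is 3000 nM, ranging from 1000 nM to 10000 nM.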

Compound 3, half-maximal inhibitory concentration: 150 nM
Estimate against measurement, compound 3: 20-fold (1.30 log units) above, and the stated range ends above it.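

Trifluoromethyl in place of bromo gives a 21-fold lower number from compound 2 to compound 3 (1.32 log units; beyond the scatter), so this one aromatic carbon, with the rest of the molecule unchanged, can carry a large step and not only the modest one seen so far. Against fluoro, the same group gives an at least 66-fold lower number from compound 1 to compound 3 (1.82 log units; beyond the scatter). That step is only a bound, set by the limit for compound 1: the limit of > 10000 nM in this assay, at which 1 of the 3 values shown sits.

Going by these compounds, what an amine, a carboxylic acid or a longer alkyl chain would do on this carbon stays open. The three values also give no cause for the gap between bromo and trifluoromethyl.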